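Bromoacetyl hydrazide series: maleimide variant, expectation

The source may hold more compounds than are shown below. What is called first, only, known or untested is meant among the compounds shown, and "the series" means these compounds.

Measured compounds:
compound 1 `CC(C)(C)OC(=O)NN(Cc1ccccc1)C(=O)CBr`, 24700 nM
compound 2 `C=CC(=O)N(Cc1ccccc1)NC(=O)OC(C)(C)C`, > 100000 nM

In an assay on isolated protein for inhibition of RAC-alpha serine/threonine-protein kinase (Homo sapiens), read by Z'-LYTE, with a stated time of 1 h, in the presence of a further agent that is not named here (on this read-out higher numbers stand for weaker inhibition and lower numbers for stronger inhibition), compound 1 gives 24700 nM. Compound 2 reaches only a limit of this assay, > 100000 nM, and so stands at the weak end of the two numbers shown; see (the limit of > 100000 nM in this assay, at which 1 of the 2 values shown sits). Among the compounds with values here, the only measured step, an at least 4.0-fold higher number from compound 1 to compound 2 (0.60 log units; beyond the scatter), shows that changing the group on the carbonyl carbon moves the read-out by at least that much.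

Compound 3 `CC(C)(C)OC(=O)NN(Cc1ccccc1)C(=O)CN1C(=O)C=CC1=O` differs from compound 2 by a group of 8 heavy atoms (5 carbon, 1 nitrogen, 2 oxygen; one five-membered non-aromatic ring with 1 hetero atom) in place of a group of 2 heavy atoms (2 carbon; no ring), on a carbonyl carbon. Within the data shown here, no measured step carries this exact change, and the step from compound 1 to compound 2 bears on it only in that the same carbonyl carbon is altered. The expectation for an at least 2.5-fold lower number from compound 2 to compound 3 (0.39 log units; beyond the scatter) is therefore a step back toward the number of compound 1, with wide uncertainty. Compound 3 is estimated at 40000 nM, with a range from 8000 nM to 200000 nM.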

Compound 3, half-maximal inhibitory concentration: 4680 nM
Estimate against measurement, compound 3: 8.5-fold (0.93 log units) above, outside the stated range (below it).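

In this assay the group of 8 heavy atoms on the carbonyl carbon gives the lowest number of the three compounds, with an at least 21-fold lower number from compound 2 to compound 3 (1.32 log units; beyond the scatter) and a 5.3-fold lower number from compound 1 to compound 3 (0.72 log units; beyond the scatter) as the two steps that show it. The earlier pair showed only a rise in the number when the group on this carbonyl carbon changed, whereas compound 3 shows that the same place can also carry a change to a lower number, with a five-membered non-aromatic ring in the entering group. The first of these steps starts from a limit of compound 2 and gives only a lower bound on its size: the limit of > 100000 nM in this assay, at which 1 of the 3 values shown sits.

Which part of the entering group goes with the lower number stays open. Also open, from the compounds shown here alone, is whether a chloromethyl group, an amine or a longer chain in this place would stand nearer to compound 3 or to compound 1.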